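Replacing 1H-indol-3-yl with 2,4-difluorophenyl: compound 3 to compound 4

A few compounds are considered here, and "the series" means these few. Any claim that something is new, unique, unknown or untested is made for them only; others in the source may bear on it.

Values measured in a functional assay on DU-145 cells (Homo sapiens) for inhibition, read by trypan blue exclusion, with a stated time of 96 h; a lower number here means a stronger inhibitor of growth, a higher number a weaker inhibitor of growth:
- Compound 1 `COc1cc(/C=C(/Sc2ccc(Br)cc2)C(=O)c2ccc(Br)cc2)ccc1O`: 1000 nM
- Compound 2 `COc1cc(/C=C(/Sc2ccc(Br)cc2)C(=O)c2ccc(Br)cc2)ccc1F`: 10000 nM
- Compound 3 `O=C(/C(=C\c1c[nH]c2ccccc12)Sc1ccc(Br)cc1)c1ccc(Br)cc1`: 1000 nM

Compound 3 stands level with compound 1 at the digits shown, and together they hold the lowest number of the three. Compound 4 `O=C(/C(=C\c1ccc(F)cc1F)Sc1ccc(Br)cc1)c1ccc(Br)cc1` differs from compound 3 by one change, 2,4-difluorophenyl in place of 1H-indol-3-yl on a double-bonded chain carbon bound to a double-bonded chain carbon.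

Among the measured compounds shown here, three measured steps bear on this change. Fluoro in place of hydroxy on an aromatic carbon gave a 10-fold higher number from compound 1 to compound 2 (1.00 log units; beyond the scatter). 1H-indol-3-yl in place of 4-hydroxy-3-methoxyphenyl gave no change at the digits printed from compound 1 to compound 3 (within the scatter). 1H-indol-3-yl in place of 4-fluoro-3-methoxyphenyl gave a 10-fold lower number from compound 2 to compound 3 (1.00 log units; beyond the scatter).

The nearest parallel is compound 2, which also carries fluorine on its phenyl group and has no hydroxy there, at 10000 nM. For the measured compounds named here, no measured compound carries 2,4-difluorophenyl, so the size of the step remains uncertain. A rise in the number in this assay is therefore expected, though perhaps not as large as the gap between compound 2 and compound 3. The expected step is a 5.0-fold higher number from compound 3 to compound 4 (0.70 log units; beyond the scatter). For compound 4 the estimated value is 5000 nM, with an expected range of 1000 nM to 20000 nM.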

Compound 4, concentration for 50% growth inhibition: 1000 nM
Compound 4: middle estimate off by 5.0-fold (0.70 log units), on the high side, and the stated range covers the measured number.
By their numbers in this assay, from the lowest: compounds 1, 3 and 4 (each within the scatter of the next); then compound 2.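

In this assay, the exchange of 1H-indol-3-yl for 2,4-difluorophenyl gives no change at the digits printed from compound 3 to compound 4 (within the scatter), and the exchange of 4-hydroxy-3-methoxyphenyl for the same group gives no change at the digits printed from compound 1 to compound 4 (within the scatter). Among the compounds shown here, compound 4 therefore shows that a group with 0 hydrogen-bond donors can stand level with compound 1 and compound 3 at this position, so the earlier link between the absence of hydroxy and a higher number, seen only in compound 2, does not hold for every fluorinated phenyl group here, with a 10-fold lower number from compound 2 to compound 4 (1.00 log units; beyond the scatter) marking the difference between the two fluorinated compounds. No evidence is available to explain why these groups give matching numbers or why compound 2 stands apart.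

The shown compounds do not separate the part played by the methoxy group from that of the second fluoro group in the step between compound 2 and compound 4, since that step changes both at once. They also leave open how this position would respond to a phenyl group carrying an amine or a carboxylic acid.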